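The source may report more compounds than this note shows. Statements on the series, on what has been measured and on what is new or still open speak of the compounds shown alone.

Working notes on the amide end of the shared core. Compound 1 `CCCN(CCC)C(=O)Cc1c(-c2ccc(OC)cc2)nn2c(CC)cc(CC)nc12` in an assay on C6 cells for displacement of a labelled ligand from Translocator protein (Rattus norvegicus), read by scintillation counting, with a stated time of 2 h (a lower number here means a stronger inhibitor, a higher number a weaker inhibitor), gives 5.57 nM. Within the data shown here, compound 2 `CCc1cc(CC)n2nc(-c3ccc(OC)cc3)c(CC(=O)N(CC)C(C)(C)C)c2n1` in this assay gives 59.1 nM, the highest of the two numbers so far; its nearest neighbour is compound 1, separated by an 11-fold higher number from compound 1 to compound 2 (1.03 log units; beyond the scatter). Compound 3 `CCc1cc(CC)n2nc(-c3ccc(OC)cc3)c(CC(=O)N(C(C)CC)C(C)CC)c2n1` is the next member: a group of 9 heavy atoms (8 carbon, 1 nitrogen; no ring) in place of a group of 7 heavy atoms (6 carbon, 1 nitrogen; no ring), on a carbonyl carbon. Among the measured compounds shown here, the only measured step that touches the same place is an 11-fold higher number from compound 1 to compound 2 (1.03 log units; beyond the scatter), a large change from one group on the carbonyl carbon to another, so this position clearly moves the number beyond the scatter. For the measured compounds named here, the group entering in compound 3 is not the one in compound 1 either, so a full return to that value is not assumed. A modest step towards a lower number is expected, with the expected step of a 3.0-fold lower number from compound 2 to compound 3 (0.47 log units; beyond the scatter) in this assay. For compound 3 the estimate in this assay is 20 nM, with a range from 5 nM to 80 nM.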

Compound 3, inhibition constant: 14.4 nM
For compound 3 the middle estimate is 1.4-fold (0.14 log units) above the measured one; low and high end bracket the measured number.
By their numbers in this assay, from the lowest: compound 1; then compound 3; then compound 2.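

In this assay, the change to bis(sec-butyl)amino gives a 4.1-fold lower number from compound 2 to compound 3 (0.61 log units; beyond the scatter), so a change on this carbonyl carbon can also bring the number down, and compound 3 recovers part of the loss seen with compound 2. The recovery is only partial: dipropylamino still holds the lowest number, with a 2.6-fold higher number from compound 1 to compound 3 (0.41 log units; beyond the scatter). Heavy-atom count does not order the three compounds, since the groups in compound 1 and compound 2 have the same count yet lie far apart, while compound 3 has the largest group and sits in the middle.

No available evidence bears on why the groups rank in this order. As far as these compounds go, it remains open whether a longer chain such as dibutylamino, or a ring such as piperidine, on this carbonyl carbon would match or pass compound 1.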